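A few compounds are considered here, and "the series" means these few. Any claim that something is new, unique, unknown or untested is made for them only; others in the source may bear on it.

Three chalcone-like compounds sharing one core were measured in a functional assay on Malme-3M cells (Homo sapiens) for cytotoxicity, read by sulforhodamine B assay, with a stated time of 48 h, tested at 10 uM; a higher number here means a weaker effect of the compound at the concentration tested, a lower number a stronger effect. Compound 1 `COc1cc(-c2cc(/C=C/C(=O)c3ccc(N)cc3)[nH]n2)cc(OC)c1OC` gives -45%, which places it second highest of the three numbers. Compound 2 `COc1ccc(-c2cc(/C=C/C(=O)c3ccc(OC)c(OC)c3)[nH]n2)cc1` gives -70%, lower than compound 1 and beyond the scatter. For the measured compounds named here, compound 3 `COc1ccc(-c2cc(/C=C/C(=O)c3ccc(N)cc3)[nH]n2)cc1OC` gives 37%, and the single change from compound 1, hydrogen in place of methoxy on an aromatic carbon, brings a step of a number 82 percentage points higher from compound 1 to compound 3 (beyond the scatter).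

Compound 4 `COc1ccc(C(=O)/C=C/c2cc(-c3cc(OC)c(OC)c(OC)c3)n[nH]2)cc1OC` is not yet measured. It differs from compound 1 at the carbonyl carbon: 3,4-dimethoxyphenyl in place of 4-aminophenyl on a carbonyl carbon. Going by the values given here, no measured pair differs by exactly this change, so no step speaks to it directly. Among the compounds with values here, compound 2, the only measured compound carrying the 3,4-dimethoxyphenyl on its carbonyl carbon, is the lowest number with -70%, but it also differs at the other aromatic ring, so its weight is limited. The expected step is therefore modest and downward, estimated as a number 15 percentage points lower from compound 1 to compound 4 (beyond the scatter). Compound 4 is expected to give about -60%, within a range from -85% to -25%.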

Compound 4, a percentage reported as activity, at one concentration (the size of the read-out at that concentration, not a potency): -82%
Compound 4: the middle estimate sits 22 percentage points above what was measured; measured number inside the range.
By their numbers in this assay, from the lowest: compound 4; then compound 2; then compound 1; then compound 3.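

For the compounds shown here, until now, the only step with a single change concerned the methoxy groups on the aromatic ring at the far end of the core; the group on the carbonyl carbon had not been varied alone. With everything else held as in compound 1, placing 3,4-dimethoxyphenyl in place of 4-aminophenyl on a carbonyl carbon gives a number 37 percentage points lower from compound 1 to compound 4 (beyond the scatter) in this assay, so the group at this position clearly affects the read-out, and a lower number here means a stronger effect. No measurement is available to explain this step.

Only these two groups can be compared at this position, so it remains unclear whether the step follows from losing the amine or from gaining the methoxy groups. A plain phenyl or a 4-hydroxyphenyl on the carbonyl carbon would help separate those two possibilities.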